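Sulfonyl to Carbonyl in a Weakly Cytotoxic Pair

This account rests on a few compounds, and the source may have more. Where it says the series, first, only, none or still open, it means among the compounds named here.

Going by the values given here, compound 2 `O=S(=O)(NCCNc1nccc(-c2c(-c3cccc(F)c3)nc3sccn23)n1)c1ccc(Br)cc1` is the only member of this set with a number in a functional assay on SK-MEL-28 cells (Homo sapiens) for cytotoxicity, read by MTT assay (a higher number here means a weaker inhibitor, a lower number a stronger inhibitor), where compound 2 gives 13500 nM. Compound 1 `O=S(=O)(NCCCNc1nccc(-c2c(-c3cccc(F)c3)nc3sccn23)n1)c1ccc(F)cc1` gives only a limit in this assay, > 20000 nM. The step of an at least 1.4-fold lower number from compound 1 to compound 2 (0.17 log units; that floor lies within the scatter) therefore cannot be sized beyond its floor (the limit of > 20000 nM in this assay, at which 1 of the 2 values shown sits). Compound 3 `O=C(NCCNc1nccc(-c2c(-c3cccc(F)c3)nc3sccn23)n1)c1c(F)cccc1F` differs from compound 2 by (2,6-difluorophenyl)carbonyl in place of (4-bromophenyl)sulfonyl on an amine nitrogen. Among the compounds with values here, no measured step touches the sulfonyl, so the one step known here offers little guidance for this change. The step of a 1.1-fold lower number from compound 2 to compound 3 (0.05 log units; within the scatter) is expected to stay within the scatter. Compound 3 is estimated at 12000 nM, between 4000 nM and 40000 nM.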

Compound 3, half-maximal inhibitory concentration: 11400 nM
Compound 3: the middle estimate sits 1.1-fold (0.02 log units) above what was measured, within the range that was stated.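

Setting (2,6-difluorophenyl)carbonyl in place of (4-bromophenyl)sulfonyl on the amine nitrogen leaves the reading in this assay within the scatter (a 1.2-fold lower number from compound 2 to compound 3 (0.07 log units; within the scatter)). In this pair, a carbonyl therefore serves as well as the sulfonyl, and the cytotoxicity remains weak. The wider step (an at least 1.7-fold lower number from compound 1 to compound 3 (0.24 log units; that floor lies within the scatter)) can be sized only to its floor: the limit of > 20000 nM in this assay, at which 1 of the 3 values shown sits.

The aromatic ring's substituents changed together with the linking group, so the two contributions remain unseparated. On these data alone, whether an amine or a carboxylic acid on that ring, or a longer chain carrying the carbonyl, would move the number beyond the scatter stays open.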